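A Methyl Added to the Outer Ring of Compound 3

This account rests on a few compounds, and the source may have more. Where it says the series, first, only, none or still open, it means among the compounds named here.

Three compounds share a core in which a sulfonamide links a pyrimidinedione to a phenyl ring that carries a triazole. In an ADME assay on GES1 cells (Homo sapiens) for cytotoxicity, read by MTT assay, with a stated time of 24 h (a higher number here means that more compound is tolerated, a lower number that less compound is tolerated), compound 1 `Cc1ccc(-n2cc(-c3ccccc3NS(=O)(=O)c3c[nH]c(=O)[nH]c3=O)nn2)cc1` gives 32400 nM, compound 2 `O=c1[nH]cc(S(=O)(=O)Nc2ccccc2-c2cn(-c3ccccc3Cl)nn2)c(=O)[nH]1` gives 20800 nM, and compound 3 `O=c1[nH]cc(S(=O)(=O)Nc2cccc(-c3cn(-c4ccccc4)nn3)c2)c(=O)[nH]1` gives 22500 nM. Compound 3 sits among the other two, and none of the three differs from another beyond the usual scatter. Compound 4 `Cc1ccc(-n2cc(-c3cccc(NS(=O)(=O)c4c[nH]c(=O)[nH]c4=O)c3)nn2)cc1` differs from compound 3 by methyl in place of hydrogen on an aromatic carbon. Going by the values given here, only one measured step bears on this change, and only loosely: a 1.6-fold lower number from compound 1 to compound 2 (0.19 log units; within the scatter), which exchanges one substituent on the aromatic nitrogen for another and stays within the scatter. Compound 1 carries the 4-methylphenyl group and compound 3 the bare phenyl, and their values also lie within the scatter of each other. A change of this kind is therefore expected to move this assay by little or nothing beyond the scatter. Compound 4 is expected to give about 25000 nM, with a range from 12000 nM to 50000 nM. This estimate corresponds to a 1.1-fold higher number from compound 3 to compound 4 (0.05 log units; within the scatter).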

Compound 4, half-maximal cytotoxic concentration: 15800 nM
For compound 4 the middle estimate is 1.6-fold (0.20 log units) above the measured one, within the range that was stated.
By their numbers in this assay, from the lowest: compounds 4, 2, 3 and 1 (each within the scatter of the next, the first and the last beyond it).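

Going by these compounds alone, this pair gives the first direct look at this change, because compound 3 and compound 4 differ in one place only: a methyl replaces hydrogen on an aromatic carbon of the outer ring, para to a large group. In this assay, the result is a 1.4-fold lower number from compound 3 to compound 4 (0.15 log units; within the scatter), so turning phenyl into 4-methylphenyl on this core does not shift the number beyond what repeated measurements would show. A single added carbon at this position is therefore tolerated without a clear change in this assay, and no measurement shown here offers any explanation for the outcome. Going by these compounds, whether a larger or different group at this carbon, such as an amine, a carboxylic acid or a longer chain, would move the number beyond the scatter remains open. So does whether the methyl would behave the same way on the other compounds in the series.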